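A few compounds are considered here, and "the series" means these few. Any claim that something is new, unique, unknown or untested is made for them only; others in the source may bear on it.

Compound 1 `O=C(CN1CCN(C/C=C\c2ccccc2)CC1)C(O)(c1ccccc1)C1CCC1`: 9.92 nM
Compound 2 `O=C(CN1CCN(Cc2ccco2)CC1)C(O)(c1ccccc1)C1CCC1`: 750 nM

In a functional assay on ileum for antagonist activity at muscarinic acetylcholine receptor M3 (Cavia porcellus) (a lower number here means a stronger inhibitor, a higher number a weaker inhibitor), compound 2 stands highest of the two measured numbers, its nearest neighbour being compound 1 at 9.92 nM. Compound 3 `O=C(CN1CCN(Cc2cccs2)CC1)C(O)(c1ccccc1)C1CCC1` is made from compound 2 by thiophen-2-yl in place of furan-2-yl on a saturated chain carbon bound to an amine nitrogen in a ring. Among the compounds with values here, no measured step covers this exchange; the only step, a 76-fold higher number from compound 1 to compound 2 (1.88 log units; beyond the scatter), concerns a different group at the same place and shows that this position can move the number a great deal. Without a bearing step, compound 3 is expected to lie close to compound 2, with a step of a 1.5-fold lower number from compound 2 to compound 3 (0.18 log units; within the scatter), and is estimated at 500 nM, between 150 nM and 1600 nM.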

Compound 3, antagonist equilibrium constant: 43.8 nM
Beside the measured number, compound 3's estimate is 11-fold (1.06 log units) above it, outside the stated range (below it).
By their numbers in this assay, from the lowest: compound 1; then compound 3; then compound 2.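

In this assay, the swap of one five-membered aromatic ring for another with the same heavy-atom count, sulfur entering where oxygen leaves, gives a 17-fold lower number from compound 2 to compound 3 (1.23 log units; beyond the scatter) on this saturated chain carbon, so the position responds to the ring's hetero atom and not only to a large change of group. The thiophen-2-yl group does not match the 2-phenylethenyl group, as a 4.4-fold higher number from compound 1 to compound 3 (0.64 log units; beyond the scatter) shows. Nothing given here accounts for the size of these steps. Still open, on these data alone, is whether a plain phenyl ring or a pyridine ring at this place would come closer to compound 1. As far as these compounds go, it is equally open whether a longer chain carrying the thiophen-2-yl group would keep the number of compound 3.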